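Notes on the series: 4-methylbenzyl to 4-fluorobenzyl

This account rests on a few compounds, and the source may have more. Where it says the series, first, only, none or still open, it means among the compounds named here.

Values in a functional assay on HCT-116 cells (Homo sapiens) for inhibition, read by MTT assay, with a stated time of 48 h; a lower number here means a stronger inhibitor, a higher number a weaker inhibitor:
- compound 1 `CCSc1nnc(-c2cc(OC)c(OC)c(OC)c2)n1-c1ccc(OC)cc1` gives > 60000 nM (a limit, not a number)
- compound 2 `COc1ccc(-n2c(SCc3ccccc3)nnc2-c2cc(OC)c(OC)c(OC)c2)cc1` gives 42400 nM
- compound 3 `COc1ccc(-n2c(SCc3ccc(C)cc3)nnc2-c2cc(OC)c(OC)c(OC)c2)cc1` gives 33300 nM

Compound 3 stands with compound 2 as its nearest neighbour on the numbers, and the two values lie within the scatter of each other (a 1.3-fold lower number from compound 2 to compound 3 (0.10 log units; within the scatter)). Compound 1 offers only a limit, so the steps of an at least 1.4-fold lower number from compound 1 to compound 2 (0.15 log units; that floor lies within the scatter) and an at least 1.8-fold lower number from compound 1 to compound 3 (0.25 log units; that floor lies within the scatter) give floors and not sizes.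

Compound 4 `COc1ccc(-n2c(SCc3ccc(F)cc3)nnc2-c2cc(OC)c(OC)c(OC)c2)cc1` differs from compound 3 by fluoro in place of methyl on an aromatic carbon, para to a large group (fluoro in place of methyl on an aromatic carbon). Among the measured compounds shown here, no measured step makes this exact exchange. The closest is the step from hydrogen to methyl on that same carbon (a 1.3-fold lower number from compound 2 to compound 3 (0.10 log units; within the scatter)), which stayed within the scatter. The steps from compound 1 change the whole group on the chain carbon and bear on it less directly.

No step beyond the scatter is expected in this assay, and no direction is favoured. The expected change is small (a 1.1-fold higher number from compound 3 to compound 4 (0.02 log units; within the scatter)). For compound 4 the estimated value is 35000 nM with an expected range of 17000 nM to 60000 nM in this read-out.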

Compound 4, half-maximal inhibitory concentration: 38700 nM
Beside the measured number, compound 4's estimate is 1.1-fold (0.04 log units) below it; low and high end bracket the measured number.
By their numbers in this assay, from the lowest: compounds 3, 4 and 2 (each within the scatter of the next). At a limit, above all of these: compound 1.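

On the aromatic carbon para to a large group, fluoro now joins methyl and hydrogen, and in this assay neither new step leaves the scatter (a 1.2-fold higher number from compound 3 to compound 4 (0.07 log units; within the scatter); a 1.1-fold lower number from compound 2 to compound 4 (0.04 log units; within the scatter)). The earlier compounds covered only the exchange of hydrogen for methyl on this carbon; the three compounds now give no sign that the choice among these three substituents matters in this read-out, and no order can be drawn among them. Against compound 1, only a floor can be read (an at least 1.5-fold lower number from compound 1 to compound 4 (0.19 log units; that floor lies within the scatter)), as that compound's value is a limit: the limit of > 60000 nM in this assay, at which 1 of the 4 values shown sits.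

Still open, from the compounds shown here alone, is whether an amine or a carboxylic acid on the same carbon would give a step beyond the scatter. A longer chain on the sulfur is equally untested by the compounds shown here.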